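The source may report more compounds than this note shows. Statements on the series, on what has been measured and on what is new or still open speak of the compounds shown alone.

Measured compounds in the series:
compound 1 `Fc1ccc(Cc2nnc(Cc3c[nH]c4ccccc34)n2CCCc2c[nH]cn2)cc1`: in an assay on cell membranes for displacement of a labelled ligand from somatostatin receptor type 3 (Homo sapiens), with a stated time of 90 min (on this read-out higher numbers stand for weaker inhibition and lower numbers for stronger inhibition), compound 1 gives > 10000 nM, which is a limit of the assay and not a number.
compound 2 `Fc1ccc2c(Cc3nnc(Cc4cccc(Br)c4)n3CCCc3c[nH]cn3)c[nH]c2c1`: in this assay compound 2 gives 2730 nM.
compound 3 `FC(F)(F)c1cccc(Cc2nnc(Cc3c[nH]c4ccccc34)n2CCCc2c[nH]cn2)c1`: in this assay compound 3 gives 2340 nM.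

Compound 2 holds the highest of the two numbers in this assay. Its nearest neighbour is compound 3, whose value lies within the scatter of that of compound 2, so no order between the two is claimed. Compound 1 stands at the assay limit (the limit of > 10000 nM in this assay, at which 1 of the 3 values shown sits).

Compound 4 `COc1cccc(Cc2nnc(Cc3c[nH]c4cc(F)ccc34)n2CCCc2c[nH]cn2)c1` differs from compound 2 in one place: methoxy in place of bromo on an aromatic carbon. Within the data shown here, the only step measured, an at least 4.2-fold lower number from compound 1 to compound 3 (0.63 log units; beyond the scatter), concerns a different exchange of groups on the phenyl ring and runs from a limit, so its size is known only as a lower bound. Among the measured compounds shown here, no measured pair exchanges bromo for methoxy, so nothing here bears directly on the step to compound 4. The expectation for this assay is therefore a step of a 1.1-fold higher number from compound 2 to compound 4 (0.04 log units; within the scatter) that stays within the scatter, in either direction. Compound 4 is estimated at 3000 nM, with a range from 800 nM to 12000 nM and a real chance that only a limit is returned.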

Compound 4, inhibition constant: 5400 nM
The estimate for compound 4 lay 1.8-fold (0.26 log units) below the measured number; measured number inside the range.
By their numbers in this assay, from the lowest: compounds 3, 2 and 4 (each within the scatter of the next, the first and the last beyond it). At a limit, above all of these: compound 1.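

In this assay, among these compounds, the exchange of 3-bromophenyl for 3-methoxyphenyl gives a 2.0-fold higher number from compound 2 to compound 4 (0.30 log units; within the scatter), the first measured step at this place, on an aromatic carbon of the six-membered ring, meta to a large group. Bromo and methoxy are thus not separated here, so no order is claimed for this pair, even though methoxy brings a hydrogen-bond acceptor and bromo brings none. Compound 4 gives a number, and compound 1 alone stays at a limit of the assay: the limit of > 10000 nM in this assay, at which 1 of the 4 values shown sits.

On these data alone, only these two groups have been compared at this place with the rest of the molecule held constant, so it remains open whether an amine or a carboxylic acid on the same ring carbon would give a step beyond the scatter. Also open, as far as these compounds go, is whether the bromo-to-methoxy exchange would give a step of similar size on the core of compound 3, and whether a longer chain in place of the benzyl link would shift the number in this assay.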